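Spirocyclic amides as orexin-2 antagonists: methyl to trifluoromethyl

The source may hold more compounds than are shown below. What is called first, only, known or untested is meant among the compounds shown, and "the series" means these compounds.

Measured so far:
compound 1, `Cc1cnn(-c2ccc(C)nc2C(=O)N2CC3(CC3)C[C@H]2CNc2ccc(C(F)(F)F)cn2)c1`: 8.3
compound 2, `Cc1ccc(-c2ncccn2)c(C(=O)N2CC3(CC3)C[C@H]2CNc2ccc(C(F)(F)F)cn2)n1`: 7.5

Both numbers come from a functional assay on HEK293 cells for antagonist activity at Orexin receptor type 2 (Homo sapiens), read by FLIPR and calcium flux; a higher number here means a more potent compound, by a factor of ten per unit of this negative logarithm, a lower number a less potent compound. Within the data shown here, compound 2 holds the lower of the two values; its nearest neighbour is compound 1, and the one measured step, a number 0.80 log units lower from compound 1 to compound 2 (beyond the scatter), lies beyond the scatter and swaps the pyrazolyl arm for a pyrimidinyl arm on the shared core.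

Compound 3, `O=C(c1nc(C(F)(F)F)ccc1-c1ncccn1)N1CC2(CC2)C[C@H]1CNc1ccc(C(F)(F)F)cn1`, keeps the pyrimidinyl arm of compound 2 and changes one place: trifluoromethyl in place of methyl on an aromatic carbon. Among the measured compounds shown here, no measured step touches this position; the single step in hand alters the aromatic substituent across the ring and says nothing about exchanging methyl for trifluoromethyl next to the ring nitrogen. The expectation therefore rests on compound 2 alone, with a wide allowance for either direction.

For compound 3 in this assay the estimate is 7.5, with a range from 6.8 to 8.2. This expected move of no change at the digits printed from compound 2 to compound 3 (within the scatter) is a placeholder of no change until the number arrives.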

Compound 3, negative logarithm of the antagonist equilibrium constant: 5
Estimate against measurement, compound 3: 2.50 log units above; measured number outside the range, below it.
By their numbers in this assay, from the lowest: compound 3; then compound 2; then compound 1.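

Trifluoromethyl in place of methyl on the aromatic carbon next to the ring nitrogen gives, in this assay, a number 2.50 log units lower from compound 2 to compound 3 (beyond the scatter), so this place on the ring is far from indifferent to the exchange. The earlier compounds shown here showed only a change of the other substituent on this ring, a number 0.80 log units lower from compound 1 to compound 2 (beyond the scatter), a modest step beside this large one, and within this short series the methyl place therefore carries the larger loss. Nothing available on these compounds accounts for the size of the drop.

The compounds shown leave open whether the loss belongs to trifluoromethyl specifically or would also appear with a hydrogen, a chlorine atom, an ethyl group or a methoxy group at this place. Among these compounds, they also leave open whether the same exchange costs as much with the 4-methyl-1H-pyrazol-1-yl arm of compound 1 as it does with the pyrimidin-2-yl arm of compound 2, since this one pair is the only reading of the methyl place so far.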